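A few compounds are considered here, and "the series" means these few. Any claim that something is new, unique, unknown or untested is made for them only; others in the source may bear on it.

Measured so far:
compound 1, `COc1cc(Cl)cc(-c2nn(-c3cccc(NC(=O)c4ccc(Cl)c(Cl)c4)c3)cc2-c2ccncc2)c1`, 63.6%
compound 2, `COc1cc(Cl)cc(-c2nn(-c3cccc(NC(=O)Nc4cc(C(F)(F)F)cc(C(F)(F)F)c4)c3)cc2-c2ccncc2)c1`, 8.99%

In a functional assay on CAKI-1 cells (Homo sapiens) for inhibition, read by sulforhodamine B assay, with a stated time of 48 h, tested at 10 uM (on this read-out lower numbers stand for a stronger effect and higher numbers for a weaker effect at the one concentration tested), compound 1 gives 63.6%, the highest of the two numbers, so the weaker of the two effects. For the measured compounds named here, compound 2, `COc1cc(Cl)cc(-c2nn(-c3cccc(NC(=O)Nc4cc(C(F)(F)F)cc(C(F)(F)F)c4)c3)cc2-c2ccncc2)c1`, gives 8.99% in this assay, a number far lower and beyond the scatter; compound 2 differs from compound 1 in more than one place, so no single step between them is counted.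

Compound 3, `COc1cc(Cl)cc(-c2nn(-c3cccc(NC(=O)c4cccc(C(F)(F)F)c4)c3)cc2-c2ccncc2)c1`, is the one not yet measured. It follows from compound 1 by a single change: 3-(trifluoromethyl)phenyl in place of 3,4-dichlorophenyl on a carbonyl carbon

Going by the values given here, no step between measured compounds bears on this change, so the expectation rests on compound 1 alone. A small step toward a lower number is expected, a number 8.6 percentage points lower from compound 1 to compound 3 (within the scatter), with a fair chance that it stays within the scatter. For compound 3 the estimate in this assay is 55%, with a range from 25% to 85%.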

Compound 3, a percentage reported as activity, at one concentration (the size of the read-out at that concentration, not a potency): 54%
For compound 3 the middle estimate is 1 percentage points above the measured one; the range from low to high includes it.
By their numbers in this assay, from the lowest: compound 2; then compounds 3 and 1 (each within the scatter of the next).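

In this assay, 3-(trifluoromethyl)phenyl in place of 3,4-dichlorophenyl on the carbonyl carbon gives a number 9.6 percentage points lower from compound 1 to compound 3 (within the scatter). For the compounds shown here, this is the first comparison that differs in one place, and it shows that at this position, with the amide-type nitrogen kept, the exchange of the two chlorine atoms for a trifluoromethyl group leaves the read-out within the scatter. No measurement available here speaks to the reason for this outcome.

Still open, from the compounds shown here alone, is how this position responds to a phenyl ring carrying a different kind of group, such as an amine or a carboxylic acid, or to a non-aromatic group such as a longer alkyl chain. The compounds shown also do not separate the urea linkage of compound 2 from its aryl group, so a urea bearing 3-(trifluoromethyl)phenyl or 3,4-dichlorophenyl would be needed to assign to one place the value of compound 2, which is 8.99%.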